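Side-chain exchange on the shared core: compound 3

The source may report more compounds than this note shows. Statements on the series, on what has been measured and on what is new or still open speak of the compounds shown alone.

Compound 2 `Cn1nnnc1SCC(=O)Nc1ccc(-c2nc(-c3ccccc3)c(-c3ccccc3)n2C)cc1` gives 77.7% in a functional assay on MCF7 cells (Homo sapiens) for cytotoxicity, read by MTT assay, with a stated time of 24 h, tested at 80 ug/mL; a higher number here means a stronger effect of the compound at the concentration tested, a lower number a weaker effect. Within the data shown here, of the two numbers so far it is nominally the higher one, but the single measured step, a number 1.4 percentage points higher from compound 1 to compound 2 (within the scatter), lies within the scatter, so compound 2 and compound 1 `Cn1c(-c2ccc(NC(=O)CSc3nc4ccccc4o3)cc2)nc(-c2ccccc2)c1-c1ccccc1`, which gives 76.3% in this assay, are not separated by the data.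

Compound 3 `CN1CCN(CC(=O)Nc2ccc(-c3nc(-c4ccccc4)c(-c4ccccc4)n3C)cc2)CC1` has not been measured in this assay. Its structure differs from compound 2 as follows: 4-methylpiperazin-1-yl in place of (1-methyl-1H-tetrazol-5-yl)sulfanyl on a saturated chain carbon bound to a carbonyl carbon. Among the measured compounds shown here, the only step that bears on this position is a number 1.4 percentage points higher from compound 1 to compound 2 (within the scatter), which exchanged one sulfur-bound aromatic ring for another and moved the read-out by no more than the scatter. For the measured compounds named here, the change to compound 3 goes further, removing the sulfur-linked ring altogether and bringing in a six-membered non-aromatic ring; no measured pair covers such an exchange, so the expectation rests on the one small step alone.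

On that basis the step of a number 7.7 percentage points lower from compound 2 to compound 3 (within the scatter) is expected to stay within or near the scatter, with a wide range to reflect the uncovered change. For compound 3 the estimate in this assay is 70%, between 48% and 86%.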

Compound 3, a percentage reported as activity, at one concentration (the size of the read-out at that concentration, not a potency): 50.3%
Estimate against measurement, compound 3: 19.7 percentage points above; the measured number falls inside the stated range.
By their numbers in this assay, from the lowest: compound 3; then compounds 1 and 2 (each within the scatter of the next).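

In this assay the position on a saturated chain carbon bound to a carbonyl carbon now proves responsive: there is a number 27.4 percentage points lower from compound 2 to compound 3 (beyond the scatter) and a number 26 percentage points lower from compound 1 to compound 3 (beyond the scatter), whereas the exchange of one sulfur-bound aromatic ring for another gave only a number 1.4 percentage points higher from compound 1 to compound 2 (within the scatter). The flatness seen with compounds 1 and 2 therefore holds only for that exchange and does not extend to replacing the sulfur-linked aromatic ring with 4-methylpiperazin-1-yl, a change that leaves the heavy-atom count of the group as it was in compound 2. No measured evidence accompanies these numbers to account for the fall.

The compounds shown do not separate the loss of the sulfur link from the arrival of the six-membered non-aromatic ring, since both change together in compound 3. A piperidin-1-yl or morpholin-4-yl group on the same carbon, an open-chain dimethylamino group, or a sulfur-bound phenyl ring would each bear on that question, and a longer chain between the carbonyl and the ring remains equally unexplored in this series.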